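This account rests on a few compounds, and the source may have more. Where it says the series, first, only, none or still open, it means among the compounds named here.

Two pairs in this set carry one and the same change. Compound 1 `C#CCN(C)CCCCOc1ccc2c(c1)OCCC2=O` gives 22.8% in an ADME assay on BTI cells for inhibition of Amine oxidase [flavin-containing] A (Homo sapiens), read by fluorescence and Amplex Red, with a stated time of 15 min, tested at 100 uM; a higher number here means more inhibition at the concentration tested (going by the name of the read-out), a lower number less inhibition. Compound 2 `C#CCN(C)CCCCCOc1ccc2c(c1)OCCC2=O` differs from it by (methyl(propargyl)amino)methyl in place of methyl(propargyl)amino on a saturated chain carbon, four bonds along the chain from an oxygen on an aromatic ring, and in this assay compound 2 gives 6.04%; the change made a number 16.8 percentage points lower from compound 1 to compound 2 (beyond the scatter). Compound 3 `C#CCN(C)CCCCOc1ccc(C=O)c(OC)c1` gives 29.4% in this assay; how its core differs from the core of compound 1 is not broken down here. Compound 4 `C#CCN(C)CCCCCOc1ccc(C=O)c(OC)c1` is not yet measured and differs from compound 3 by (methyl(propargyl)amino)methyl in place of methyl(propargyl)amino on a saturated chain carbon, four bonds along the chain from an oxygen on an aromatic ring, the same change at the same place as in the first pair. Resting on the single measured step of a number 16.8 percentage points lower from compound 1 to compound 2 (beyond the scatter), a step of similar size is expected, namely a number 16.4 percentage points lower from compound 3 to compound 4 (beyond the scatter). Compound 4 is thus estimated at 13%, expected to fall between 2% and 26%.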

Compound 4, a percentage reported as inhibition, at one concentration (the size of the read-out at that concentration, not a potency): 27.1%
Beside the measured number, compound 4's estimate is 14.1 percentage points below it, and the stated range ends below it.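

In this assay, the lengthening to (methyl(propargyl)amino)methyl gives a number 2.3 percentage points lower from compound 3 to compound 4 (within the scatter), so the step seen on the core of compound 1 does not carry over in size to the core of compound 3: the same change on two cores in this assay, a number 16.8 percentage points lower (beyond the scatter) from compound 1 to compound 2 and a number 2.3 percentage points lower (within the scatter) from compound 3 to compound 4, 14.5 percentage points apart, beyond the scatter of two such steps.
The size of this step therefore depends on the core in these four compounds, and a step read on one of these cores is a poor guide to the other. With one pair per core, all tested at a single concentration, this does not show which feature of the cores is responsible or how a third core would behave.

Still open, from the compounds shown here alone, is whether a longer chain continues either trend. Also open, going by these compounds, is whether the core dependence persists with a dimethylamine in place of the methyl(propargyl)amino end.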